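Notes on an isomeric amine exchange in the series

This account rests on a few compounds, and the source may have more. Where it says the series, first, only, none or still open, it means among the compounds named here.

Measured in a physicochemical assay for lipophilicity; on this read-out higher numbers stand for higher lipophilicity and lower numbers for lower lipophilicity:
- compound 1 `CCN(CC)c1c(C)n(CC)c(=O)n(-c2ccccc2)c1=O`: 2.2
- compound 2 `CCN(CC)c1c(C)n(C)c(=O)n(-c2ccccc2)c1=O`: 2.11
- compound 3 `Nc1nc(N)nc(-c2cc(C(F)(F)F)ccc2Cl)n1`: 2.27

In this assay the value of compound 2 lies within the scatter of both compound 1 and compound 3. Compound 4 `CCCCNc1c(C)n(C)c(=O)n(-c2ccccc2)c1=O` is not yet measured. It differs from compound 2 by butylamino in place of diethylamino on an aromatic carbon. The two have the same atoms, joined differently. Among the compounds with values here, the only measured step, a number 0.09 log units lower from compound 1 to compound 2 (within the scatter), concerns a different place, and no measured step covers this exchange. It offers only weak guidance, so no change beyond the scatter is expected in this assay. The expected step is a number 0.14 log units higher from compound 2 to compound 4 (within the scatter). The estimated value for compound 4 is 2.25, with an expected range from 1.8 to 2.7.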

Compound 4, partition coefficient: 1.69
The estimate for compound 4 lay 0.56 log units above the measured number; the measured number lies below the stated range.
By their numbers in this assay, from the lowest: compound 4; then compounds 2, 1 and 3 (each within the scatter of the next).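

In this assay, this position on the aromatic carbon is sensitive to how the same atoms are joined: butylamino in place of diethylamino gives a number 0.42 log units lower from compound 2 to compound 4 (beyond the scatter) and thus a step beyond the scatter, which the earlier step at a different place did not show. Butylamino has 1 hydrogen-bond donor where diethylamino has 0, while the heavy atoms stay the same. Nothing available ties this step to a cause.

Open, going by these compounds, is whether dimethylamino or a longer chain such as hexylamino would follow compound 4 or compound 2. Also open, on these data alone, is whether the same exchange gives a similar step on the core of compound 1.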